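A Carboxy Group Replaces Fluorine on an Aromatic Ring

This account rests on a few compounds, and the source may have more. Where it says the series, first, only, none or still open, it means among the compounds named here.

Of the compounds shown here, three sharing one large core have been measured in a functional assay on HT-29 cells (Homo sapiens) for cytotoxicity, read by sulforhodamine B assay; on this read-out lower numbers stand for stronger inhibition and higher numbers for weaker inhibition. Compound 1 `C=C1[C@@H](C/C=C2/C(=O)OC[C@H]2OC(C)=O)[C@]2(C)CC[C@@H](OC(C)=O)[C@@](C)(CO[Si](C)(C)C(C)(C)C)[C@H]2C[C@@H]1O` gives 9310 nM. Compound 2 `C=C1[C@@H](OC(C)=O)C[C@@H]2[C@](C)(CO[Si](C)(C)C(C)(C)C)[C@H](OC(C)=O)CC[C@@]2(C)[C@@H]1C[C@@H](Nc1ccccc1F)C1=CCOC1=O` gives 3710 nM, the lowest of the three numbers and so the strongest inhibition seen so far; compound 1 and compound 3 both lie beyond the scatter above it. Compound 3 `C=C1[C@@H](OC(C)=O)C[C@@H]2[C@](C)(COC=O)[C@H](OC(C)=O)CC[C@@]2(C)[C@@H]1C[C@@H](Nc1ccccc1F)C1=CCOC1=O` gives 9760 nM; it differs from compound 2 only in the group sitting on an oxygen on a saturated carbon, and the step from compound 2 to compound 3 was a 2.6-fold higher number from compound 2 to compound 3 (0.42 log units; beyond the scatter).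

Compound 4 `C=C1[C@@H](OC(C)=O)C[C@@H]2[C@](C)(CO[Si](C)(C)C(C)(C)C)[C@H](OC(C)=O)CC[C@@]2(C)[C@@H]1C[C@@H](Nc1ccccc1C(=O)O)C1=CCOC1=O` has not yet been measured. It differs from compound 2 on the aromatic ring carried by the amino group: carboxy in place of fluoro on an aromatic carbon. The (2-fluorophenyl)amino group thus becomes a (2-carboxyphenyl)amino group. Within the data shown here, the single measured step concerns a different part of the molecule, so no measured step bears on this change, and nothing shows how this ring tolerates substitution. The expectation can only be a number close to that of compound 2, with a broad range. Compound 4 is therefore estimated to give 5000 nM, between 1500 nM and 20000 nM. The step from compound 2 to compound 4 is expected to be a 1.3-fold higher number from compound 2 to compound 4 (0.13 log units; within the scatter), a change within the scatter.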

Compound 4, half-maximal inhibitory concentration: 5340 nM
The estimate for compound 4 lay 1.1-fold (0.03 log units) below the measured number; the measured number falls inside the stated range.
By their numbers in this assay, from the lowest: compounds 2, 4, 1 and 3 (each within the scatter of the next, the first and the last beyond it).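

In this assay, putting carboxy in place of fluoro on this aromatic carbon gives a 1.4-fold higher number from compound 2 to compound 4 (0.16 log units; within the scatter), so compound 2 and compound 4 cannot be told apart on this read-out. Among these compounds, this is the first look at the aromatic ring carried by the amino group, and it shows that this place accepts a larger group with a hydrogen-bond donor and a hydrogen-bond acceptor, where fluoro has neither, with no change beyond the usual scatter, whereas the change at the other end of the core gave a 2.6-fold higher number from compound 2 to compound 3 (0.42 log units; beyond the scatter). No measurement of any property of these groups accompanies the numbers, so the result can be recorded but not explained.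

The compounds shown leave open whether a methyl ester, a primary amide, an amine or plain hydrogen at this ring carbon would also leave the number in the same range, which would tell how much this place tolerates in general. They also leave open how the carboxy group would behave in a compound that carries the smaller group of compound 3 on the oxygen in place of the silyl group.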